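The source may report more compounds than this note shows. Statements on the series, on what has been measured and on what is new or still open speak of the compounds shown alone.

Measured so far in this series:

compound 1 `COc1cccc(/C=C2\CCC/C(=C\c3ccc(Br)cc3)C2=O)c1OC` – 11100 nM
compound 2 `COc1cccc(/C=C2\CCC/C(=C\c3ccc(O)c(O)c3)C2=O)c1OC` – 6300 nM
compound 3 `COc1ccc(/C=C2\CCC/C(=C\c3ccc(Cl)cc3)C2=O)cc1OC` – 5900 nM

In a functional assay on SW-620 cells (Homo sapiens) for cytotoxicity, read by MTT assay, with a stated time of 72 h (a higher number here means a weaker inhibitor, a lower number a stronger inhibitor), compound 3 gives the lowest number of the three, though its gaps to compound 2 and to compound 1 both lie within the scatter, so no ranking among them is claimed. Compound 4 `COc1ccc(/C=C2\CCC/C(=C\c3cc(Cl)cc(Cl)c3)C2=O)cc1OC` is not yet measured; it differs from compound 3 by 3,5-dichlorophenyl in place of 4-chlorophenyl on a double-bonded chain carbon bound to a double-bonded ring carbon. Going by the values given here, the only measured step at the same place is a 1.8-fold lower number from compound 1 to compound 2 (0.25 log units; within the scatter), an exchange of one aryl group for another that stays within the scatter. Among the compounds with values here, no measured step tests adding a second chlorine at this place. A step of a 1.1-fold lower number from compound 3 to compound 4 (0.03 log units; within the scatter) is therefore expected, nothing beyond the scatter. Compound 4 is estimated at 5500 nM, with a range of 2500 nM to 12000 nM.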

Compound 4, half-maximal inhibitory concentration: 2500 nM
Beside the measured number, compound 4's estimate is 2.2-fold (0.34 log units) above it; the measured number falls inside the stated range.
By their numbers in this assay, from the lowest: compound 4; then compounds 3, 2 and 1 (each within the scatter of the next).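

In this assay, going by these compounds alone, 3,5-dichlorophenyl in place of 4-chlorophenyl gives a 2.4-fold lower number from compound 3 to compound 4 (0.37 log units; beyond the scatter), the only step at this place that lies beyond the scatter. The number therefore can respond to the aryl group on a double-bonded chain carbon bound to a double-bonded ring carbon, which a 1.8-fold lower number from compound 1 to compound 2 (0.25 log units; within the scatter) could not show. The data at hand offer no explanation for this step. Still open, on these data alone, is how an amine or a carboxylic acid on this aryl group would read, and whether the step persists when the other aryl group of compound 3 changes.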